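Removing a Methyl from an Aromatic Oxygen in Compound 4

The compounds below may be only part of what the source reports. "The series", "measured", "known", "first", "only" and "open" are said of these compounds alone.

Measured in a functional assay on HT-1080 cells (Homo sapiens) for cytotoxicity, read by MTT assay, with a stated time of 72 h; on this read-out lower numbers stand for stronger inhibition and higher numbers for weaker inhibition:
compound 1 `COc1ccc(/C=C2\CCC/C(=C\c3cccc(OC)c3OC)C2=O)cc1`, 16300 nM
compound 2 `COc1cccc(/C=C2\CCC/C(=C\c3ccc(O)cc3)C2=O)c1OC`, > 20000 nM
compound 3 `COc1cc(/C=C2\CCC/C(=C\c3cccc(OC)c3OC)C2=O)ccc1O`, 5900 nM

In this assay compound 3 gives the lowest of the two plain numbers, and compound 1 sits above it by a 2.8-fold lower number from compound 1 to compound 3 (0.44 log units; beyond the scatter), a step that accompanies the change (4-hydroxy-3-methoxyphenyl in place of 4-methoxyphenyl on a double-bonded chain carbon bound to a double-bonded ring carbon). For compound 2 the value > 20000 nM is a limit of the assay, not a number (the limit of > 20000 nM in this assay, at which 1 of the 3 values shown sits). The change hydrogen in place of methyl on an oxygen on an aromatic ring therefore gave only an at least 1.2-fold higher number from compound 1 to compound 2 (0.08 log units; that floor lies within the scatter). The step of an at least 3.3-fold lower number from compound 2 to compound 3 (0.53 log units; beyond the scatter) is likewise bounded on one side.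

Compound 4 `COc1cccc(/C=C2\CCC/C(=C\c3ccc(O)c(O)c3)C2=O)c1OC` has not been measured. It differs from compound 3 by hydrogen in place of methyl on an oxygen on an aromatic ring, the same change at the same kind of place as from compound 1 to compound 2, while the two cores differ by 4-hydroxy-3-methoxyphenyl in place of 4-methoxyphenyl on a double-bonded chain carbon bound to a double-bonded ring carbon.

The earlier step is expected to repeat roughly, so compound 4 is expected to move by a 1.5-fold higher number from compound 3 to compound 4 (0.18 log units; within the scatter), resting on an at least 1.2-fold higher number from compound 1 to compound 2 (0.08 log units; that floor lies within the scatter). Compound 4 is estimated at 9000 nM, most likely between 4000 nM and 20000 nM.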

Compound 4, half-maximal inhibitory concentration: 4700 nM
For compound 4 the middle estimate is 1.9-fold (0.28 log units) above the measured one, and the stated range covers the measured number.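

In this assay, hydrogen in place of methyl on an oxygen on an aromatic ring gives a 1.3-fold lower number from compound 3 to compound 4 (0.10 log units; within the scatter), while the larger moves come with other changes: 3,4-dihydroxyphenyl in place of 4-methoxyphenyl gives a 3.5-fold lower number from compound 1 to compound 4 (0.54 log units; beyond the scatter), and an added hydroxy group on an aromatic carbon gives an at least 4.2-fold lower number from compound 2 to compound 4 (0.62 log units; beyond the scatter). Carrying the methyl-to-hydrogen change from one core to the other shows no clear difference between the two cases, but it does not prove that they match: the same change on two cores in this assay, an at least 1.2-fold higher number (0.08 log units; that floor lies within the scatter) from compound 1 to compound 2 and a 1.3-fold lower number (0.10 log units; within the scatter) from compound 3 to compound 4; the limit leaves it open whether they differ. Compound 2 stands at > 20000 nM, which is a limit of the assay and not a number: the limit of > 20000 nM in this assay, at which 1 of the 4 values shown sits.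

The compounds shown leave open how the read-out would respond to an amine or a carboxylic acid in place of a hydroxy group on the 3,4-dihydroxyphenyl. They also leave open what a longer chain, such as ethyl, would do in place of methyl on the aromatic oxygen.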